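The source may hold more compounds than are shown below. What is called first, only, known or untested is meant among the compounds shown, and "the series" means these compounds.

Measured so far:
Compound 1 `N#Cc1c(-c2ccccc2)nc(SCC(=O)Nn2c(COc3ccc(Cl)cc3Cl)nc3ccccc3c2=O)[nH]c1=O` — 80.8%
Compound 2 `N#Cc1c(-c2ccc(Cl)cc2)nc(SCC(=O)Nn2c(COc3ccc(Cl)cc3Cl)nc3ccccc3c2=O)[nH]c1=O` — 61.5%

In a functional assay on the whole organism (strain albino) for inhibition, with Rattus norvegicus as the target, read by paw edema, with stated times of 1 h and 0.5 h, at a dose of 100 mg/kg by the oral route (a lower number here means less inhibition, a higher number more inhibition at the dose given (going by the name of the read-out)), compound 2 stands lowest of the two numbers, with compound 1 a number 19.3 percentage points lower from compound 1 to compound 2 (beyond the scatter). Compound 3 `N#Cc1c(-c2ccc(O)cc2)nc(SCC(=O)Nn2c(COc3ccc(Cl)cc3Cl)nc3ccccc3c2=O)[nH]c1=O` differs from compound 2 by hydroxy in place of chloro on an aromatic carbon. Among the compounds with values here, the only measured step that touches this position is a number 19.3 percentage points lower from compound 1 to compound 2 (beyond the scatter), where chloro replaced hydrogen; no step shows hydroxy at this place. Taking away the chloro is therefore expected to recover part of that loss, so the estimated step is a number 8.5 percentage points higher from compound 2 to compound 3 (within the scatter), upward and modest. Compound 3 is expected to give about 70%, between 52% and 88%.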

Compound 3, a percentage reported as inhibition, in the whole organism at one dose (the size of the read-out at that dose, not a potency): 61.5%
Estimate against measurement, compound 3: 8.5 percentage points above; measured number inside the range.
By their numbers in this assay, from the lowest: compounds 2 and 3 (each within the scatter of the next); then compound 1.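

In this assay, hydroxy in place of chloro gives no change at the digits printed from compound 2 to compound 3 (within the scatter) and so does not undo the drop seen with chloro. Hydroxy in place of hydrogen gives a number 19.3 percentage points lower from compound 1 to compound 3 (beyond the scatter) and shows that two different groups on this aromatic carbon read alike, with both under the compound carrying hydrogen. No measurement at hand explains this match. As far as these compounds go, whether an amine, a methoxy group or a longer chain at this place would also read lower than hydrogen stays open. So does whether the same change would matter elsewhere on the ring.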